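A few compounds are considered here, and "the series" means these few. Any claim that something is new, unique, unknown or untested is made for them only; others in the source may bear on it.

Two compounds share a common core and differ only in the group carried on the saturated chain carbon bound to a nitrogen on an aromatic ring. Compound 1 `Nc1cc(N)c2nc(-c3ccccc3)c(NCc3ccc(Cl)c(Cl)c3)nc2c1` carries a 3,4-dichlorophenyl there, compound 2 `COc1ccc(CNc2nc3cc(N)cc(N)c3nc2-c2ccccc2)cc1OC` a 3,4-dimethoxyphenyl. In a functional assay on NCI-H322M cells (Homo sapiens) for inhibition, read by sulforhodamine B assay, with a stated time of 48 h (on this read-out higher numbers stand for lower toxicity in this test and lower numbers for higher toxicity in this test), compound 1 gives 69200 nM, and compound 2 gives 100000 nM. The step of a 1.4-fold higher number from compound 1 to compound 2 (0.16 log units; within the scatter) is the only measured one and stays within the scatter. Of the two numbers shown, the one for compound 2 is the higher, but since its only neighbour, compound 1, lies within the scatter of it, no real order between them can be claimed.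

Compound 3 `COc1cc(CNc2nc3cc(N)cc(N)c3nc2-c2ccccc2)cc(OC)c1OC` is not yet measured. It differs from compound 2 by methoxy in place of hydrogen on an aromatic carbon, ortho to a methoxy group and meta to a methoxy group. For the measured compounds named here, no measured step tests this exact change; the one step known, from compound 1 to compound 2, exchanged the ring substituents wholesale and did not move the number beyond the scatter. On that slim basis the added methoxy is expected to leave the number about where it is, so the step of no change at the digits printed from compound 2 to compound 3 (within the scatter) is expected to stay within the scatter. Compound 3 is therefore estimated at 100000 nM, within 50000 nM to 200000 nM.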

Compound 3, concentration lethal to 50% of the cells: < 50200 nM
Compound 3 was reported as a limit; the forecaster's own chance of this, stated with the estimate: 35%; at least 1.9-fold (0.29 log units) between middle value and limit.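

Compound 3 is recorded as a limit and not as a number: the limit of < 50200 nM in this assay, at which 1 of the 3 values shown sits.

In this assay, putting methoxy in place of hydrogen on an aromatic carbon, ortho to a methoxy group and meta to a methoxy group, gives an at least 1.9-fold lower number from compound 2 to compound 3 (0.29 log units; that floor lies within the scatter); this is the first step shown that alters a single position on this aromatic ring, where the earlier step exchanged both ring substituents together. The step points towards lower numbers, which on this read-out stand for higher toxicity in this test, and the real gap may be wider than its floor, but the floor alone does not establish a real change.

The compounds shown leave open how far the true value of compound 3 lies from that of compound 2, and whether the outcome depends on methoxy itself or on the presence of any group at this place. A hydroxy group, an amine or a longer chain such as ethoxy on the same aromatic carbon would help separate these possibilities.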